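The source may hold more compounds than are shown below. What is called first, only, known or untested is meant among the compounds shown, and "the series" means these compounds.

Compound 3 `Cc1ccc(S(=O)(=O)N2N=C(c3cc4ccccc4oc3=O)CC2c2ccccc2)cc1` was studied in a functional assay on PC-3 cells (Homo sapiens) for cytotoxicity, read by MTT assay, with a stated time of 48 h; a lower number here means a stronger inhibitor, a higher number a weaker inhibitor. Compound 3 gives 48600 nM. Two other compounds stand beside it. Compound 2 `O=c1oc2ccccc2cc1C1=NN(S(=O)(=O)c2ccc([N+](=O)[O-])cc2)C(c2ccccc2)C1` gives 46600 nM in this assay, and compound 1 `CC(=O)Oc1ccccc1C1CC(C)=NN1C(=O)CN1CCC(O)CC1` gives 25600 nM; both of these lie within the scatter of compound 3, so no order among the three can be drawn. Going by the values given here, the one step measured, a 1.0-fold higher number from compound 2 to compound 3 (0.02 log units; within the scatter), concerns a substituent on an aromatic carbon and not the position changed here.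

Compound 4 `O=C(CN1CCC(O)CC1)N1N=C(c2cc3ccccc3oc2=O)CC1c1ccccc1` differs from compound 3 as follows: ((4-hydroxypiperidin-1-yl)methyl)carbonyl in place of (4-methylphenyl)sulfonyl on an amine nitrogen in a ring. Among the compounds with values here, no measured step concerns this exchange. Compound 1 carries the entering group on a ring nitrogen of a different core, and its number and that of compound 3 lie within the scatter of each other, which offers no sign of a shift in either direction. The step of a 1.6-fold lower number from compound 3 to compound 4 (0.21 log units; within the scatter) is therefore expected to stay within the scatter. Compound 4 is estimated at 30000 nM, with a range from 10000 nM to 90000 nM.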

Compound 4, half-maximal inhibitory concentration: "not active" (no number reported)
The entry for compound 4 holds no number; no gap can be computed for the estimate.
By their numbers in this assay, from the lowest: compounds 1, 2 and 3 (each within the scatter of the next).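

Going by these compounds alone, compound 4 is entered as "not active" with no number in this assay, so no step from compound 3 to compound 4 can be read. Nothing at hand gives an explanation for this result. The compounds shown leave open how far ((4-hydroxypiperidin-1-yl)methyl)carbonyl in place of (4-methylphenyl)sulfonyl shifts the number on the shared core.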